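The source may report more compounds than this note shows. Statements on the series, on what has been measured and on what is new or still open speak of the compounds shown alone.

Of the compounds shown here, two sharing one core have so far been tested in a functional assay on MCF7 cells (Homo sapiens) for antiproliferative activity, read by CellTiter-Glo, with a stated time of 5 days; on this read-out lower numbers stand for stronger inhibition and higher numbers for weaker inhibition. Compound 1 `O=C(O)/C=C/c1ccc(/C(=C(\c2ccccc2)C2CCC2)c2ccc(-c3cncs3)cc2)cc1` gives 9.2 nM in this assay. Compound 2 `N#Cc1ccc(/C(=C(\c2ccc(/C=C/C(=O)O)cc2)c2ccc(-c3cncs3)cc2)C2CCC2)c(Cl)c1` carries a 2-chloro-4-cyanophenyl in place of phenyl on a double-bonded chain carbon bound to a double-bonded chain carbon and a saturated ring carbon, and in this assay compound 2 gives 2.9 nM. Among the compounds with values here, that single change is a 3.2-fold lower number from compound 1 to compound 2 (0.50 log units; beyond the scatter), so compound 2 holds the lowest number of the two measured, with compound 1 as the only neighbour.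

Compound 3 `O=C(O)/C=C/c1ccc(/C(=C(\c2ncc(C(F)(F)F)cc2Cl)C2CCC2)c2ccc(-c3cncs3)cc2)cc1` has not yet been measured. It differs from compound 2 in one place: 3-chloro-5-(trifluoromethyl)pyridin-2-yl in place of 2-chloro-4-cyanophenyl on a double-bonded chain carbon bound to a double-bonded chain carbon and a saturated ring carbon. Within the data shown here, only the step from compound 1 to compound 2 touches this position, and it showed that exchanging the aromatic ring there can move the number beyond the scatter. Compound 3 keeps a chlorine on the ring that enters and adds a trifluoromethyl, while the nitrile leaves, so a shift of similar size in either direction cannot be excluded. In this assay the expected step is a 1.6-fold higher number from compound 2 to compound 3 (0.19 log units; within the scatter). Compound 3 is therefore estimated at 4.5 nM, within 1.5 nM to 14 nM.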

Compound 3, half-maximal inhibitory concentration: 7.3 nM
Compound 3: the middle estimate sits 1.6-fold (0.21 log units) below what was measured; the range from low to high includes it.
By their numbers in this assay, from the lowest: compound 2; then compounds 3 and 1 (each within the scatter of the next).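

In this assay, this position on the double-bonded chain carbon now shows that a chlorine on the aromatic ring is no guarantee of a low number: 3-chloro-5-(trifluoromethyl)pyridin-2-yl in place of 2-chloro-4-cyanophenyl gives a 2.5-fold higher number from compound 2 to compound 3 (0.40 log units; beyond the scatter) and leaves compound 2 as the most potent of the three. Measured against the plain phenyl, the same pyridine ring gives a 1.3-fold lower number from compound 1 to compound 3 (0.10 log units; within the scatter) and so does not retain the gain that 2-chloro-4-cyanophenyl brought, which means the two chlorine-bearing rings are not interchangeable at this position. No measurement at hand explains why these rings differ.

This single swap changes three things at once: a ring carbon becomes nitrogen, the nitrile leaves and a trifluoromethyl enters, and the three compounds cannot show which of these changes accounts for the step. A pyridine ring carrying a nitrile in place of the trifluoromethyl would begin to separate them, while an amine or a methoxy group on the ring would show how much other substituents can move the number.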